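Trimming the Side Chain: From Compound 1 to Compound 3

The source may hold more compounds than are shown below. What is called first, only, known or untested is meant among the compounds shown, and "the series" means these compounds.

The account concerns two measured compounds and one that is yet to be tested. In a functional assay on HCT-116 cells (Homo sapiens) for antiproliferative activity, read by CCK-8 assay, with a stated time of 72 h, tested at 8 uM (on this read-out lower numbers stand for a weaker effect and higher numbers for a stronger effect at the one concentration tested), compound 1 `COC(CCn1cnc2c(NCc3ccc(C(=O)Nc4ccccc4N)cc3)nc(Cl)nc21)OC` gives 11.9%. Compound 2 `Nc1ccccc1NC(=O)/C=C/c1ccc(COCNc2nc(Nc3cccc(Cl)c3)c3ncn(C4CCCC4)c3n2)cc1`, which shares the aminophenyl amide motif but differs in many places, gives 9.19% in this assay. Going by the values given here, the two numbers lie within the scatter of one another, so neither compound can be ranked against the other on this read-out; both values are modest at the single concentration tested, and no single-point step between them is defined.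

Compound 3 `CCCn1cnc2c(NCc3ccc(C(=O)Nc4ccccc4N)cc3)nc(Cl)nc21` is the next compound to be measured in this assay. It differs from compound 1 in one place: methyl in place of dimethoxymethyl on a saturated chain carbon, two bonds along the chain from an aromatic nitrogen. Among the compounds with values here, since no step between measured compounds is available to guide the expectation, and since compound 1 gives only 11.9%, compound 3 is expected to show a step of a number 0.1 percentage points higher from compound 1 to compound 3 (within the scatter), which is to say no change beyond the scatter. Compound 3 is therefore estimated at 12%, with a range from 2% to 25%.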

Compound 3, a percentage reported as inhibition, at one concentration (the size of the read-out at that concentration, not a potency): 29.6%
Compound 3: middle estimate off by 17.6 percentage points, on the low side; the measured number lies above the stated range.
By their numbers in this assay, from the lowest: compounds 2 and 1 (each within the scatter of the next); then compound 3.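

In this assay, replacing dimethoxymethyl with methyl on a saturated chain carbon, two bonds along the chain from an aromatic nitrogen, gives a number 17.7 percentage points higher from compound 1 to compound 3 (beyond the scatter) and is the only step shown that can be read. It shows that the read-out at the one concentration tested responds to what this carbon carries, which the two earlier compounds could not show, as they differ in many places and lie within the scatter of each other. In this single change, the five heavy atoms and two hydrogen-bond acceptors of dimethoxymethyl give way to the one carbon of methyl, and no measurement here explains why the number moves with it.

The compounds shown leave open whether the step follows the loss of the two oxygens or the loss of the size of the group, since this one change removes both together. Also open, from the compounds shown here alone, is what a hydroxyl group, an amine or a longer chain such as butyl at this place would do to the number, and how compound 3 would behave over a range of concentrations.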